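Rearranging the Bicyclic Amide Substituent of Compound 2

The source may hold more compounds than are shown below. What is called first, only, known or untested is meant among the compounds shown, and "the series" means these compounds.

Compound 1, `Cc1nc2cc(NC(=O)N3CCN(Cc4cccc(Oc5ccc(Cl)cc5)c4)CC3)ccc2o1`: 7.7 nM
Compound 2, `O=C(Nc1cn2ccccc2n1)N1CCN(Cc2cccc(Oc3ccc(Cl)cc3)c2)CC1`: > 10000 nM

In an assay on isolated protein for inhibition of Fatty-acid amide hydrolase 1 (Homo sapiens), with a stated time of 60 min (a higher number here means a weaker inhibitor, a lower number a stronger inhibitor), compound 1 gives 7.7 nM. Compound 2 reaches only > 10000 nM in this assay, which is a limit of the assay and not a number. Among the measured compounds shown here, the one measured step, an at least 1200-fold higher number from compound 1 to compound 2 (3.11 log units; beyond the scatter), shows how much the substituent on the amide-type nitrogen matters, and compound 2 sits at the limit of > 10000 nM in this assay, at which 1 of the 2 values shown sits.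

Compound 3, `O=C(Nc1ccn2ccnc2c1)N1CCN(Cc2cccc(Oc3ccc(Cl)cc3)c2)CC1`, differs from compound 2 by a group of 9 heavy atoms (7 carbon, 2 nitrogen; one five-membered aromatic ring with 2 hetero atoms, one six-membered aromatic ring with 1 hetero atom) in place of a group of 9 heavy atoms (7 carbon, 2 nitrogen; one five-membered aromatic ring with 2 hetero atoms, one six-membered aromatic ring with 1 hetero atom), on an amide-type nitrogen. For the measured compounds named here, no measured step concerns this rearrangement itself; the step of an at least 1200-fold higher number from compound 1 to compound 2 (3.11 log units; beyond the scatter) covers a different exchange and only shows that the number responds strongly to this part of the molecule. Compound 3 is therefore expected to stay weak, with an estimated 8000 nM in a range from 1000 nM to 50000 nM. The expected step of an at least 1.2-fold lower number from compound 2 to compound 3 (0.09 log units; that floor lies within the scatter) is small and uncertain in direction.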

Compound 3, half-maximal inhibitory concentration: 33 nM
Beside the measured number, compound 3's estimate is 240-fold (2.38 log units) above it, outside the stated range (below it).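

With the same atoms joined differently on the amide-type nitrogen, this assay shows an at least 300-fold lower number from compound 2 to compound 3 (2.48 log units; beyond the scatter), so at this position the arrangement of the bicyclic group decides the result, not just its atom count or ring types. Compound 2 stands at a limit of the assay and not at a number: the limit of > 10000 nM in this assay, at which 1 of the 3 values shown sits. The comparison with the other bicyclic group shows a 4.3-fold higher number from compound 1 to compound 3 (0.63 log units; beyond the scatter), so the rearranged group comes close to that of compound 1 without matching it.

The compounds shown leave open which of the changed ring connections accounts for the recovery, and whether a single pyridine ring on the amide-type nitrogen would be enough. They also do not tell whether a methoxy group or a fluorine on the group of compound 3 would close the remaining gap.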